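What one chloro might do to compound 2

This account rests on a few compounds, and the source may have more. Where it says the series, first, only, none or still open, it means among the compounds named here.

Compound 1 `Cc1nnc(-c2nn(-c3ccccc3)c(-c3ccccc3)c2C#N)c2cn(-c3ccccc3)nc12`: 8460 nM
Compound 2 `N#Cc1c(-c2nnc(-c3nn(-c4ccccc4)c(-c4ccccc4)c3C#N)c3nn(-c4ccccc4)cc23)nn(-c2ccccc2)c1-c1ccccc1`: 17800 nM

Both compounds were tested in a functional assay on MCF7 cells (Homo sapiens) for inhibition, read by sulforhodamine B assay, with a stated time of 48 h; a lower number here means a stronger inhibitor of growth, a higher number a weaker inhibitor of growth. Of these two, compound 2 has the higher number, 17800 nM, which makes it the weaker growth inhibitor, and its gap to compound 1 lies just beyond the usual scatter.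

Compound 3 `N#Cc1c(-c2nnc(-c3nn(-c4ccccc4)c(-c4ccccc4)c3C#N)c3nn(-c4ccc(Cl)cc4)cc23)nn(-c2ccccc2)c1-c1ccccc1` differs from compound 2 in one place: chloro in place of hydrogen on an aromatic carbon. This puts chloro in place of hydrogen on an aromatic carbon, turning a phenyl into a 4-chlorophenyl, para to a large group. Going by the values given here, no measured pair shows what such a change does, so the expectation rests on compound 2 alone. A step beyond the scatter is not expected in this assay, in either direction. The estimated change is small, a 1.2-fold lower number from compound 2 to compound 3 (0.07 log units; within the scatter). For compound 3 the expected value is 15000 nM, with an estimated range of 6000 nM to 40000 nM.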

Compound 3, concentration for 50% growth inhibition: 9420 nM
Estimate against measurement, compound 3: 1.6-fold (0.20 log units) above; the measured number falls inside the stated range.
By their numbers in this assay, from the lowest: compounds 1, 3 and 2 (each within the scatter of the next, the first and the last beyond it).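

In this assay, going by these compounds alone, the swap of hydrogen for chloro that turns a phenyl into a 4-chlorophenyl gives a 1.9-fold lower number from compound 2 to compound 3 (0.28 log units; within the scatter) and so supplies the first measured pair for this change. The step lies within the usual scatter, so at this aromatic carbon, para to a large group, a chloro is tolerated, and the growth-inhibition numbers of the two compounds cannot be told apart. Nothing at hand explains this result or shows what the chloro does inside the cells.

As far as these compounds go, whether a fluoro, a methoxy or an amine at the same carbon would also stay within the scatter remains open. From the compounds shown here alone, it is equally open whether a chloro on another of the phenyl rings, or the same swap on compound 1, would give a similar result.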